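Changing the Amine Ring at the End of the Chain

The source may report more compounds than this note shows. Statements on the series, on what has been measured and on what is new or still open speak of the compounds shown alone.

Of the compounds shown here, three have so far been measured in an assay on isolated protein for binding affinity to histamine H2 receptor (Homo sapiens); a higher number here means a weaker inhibitor, a lower number a stronger inhibitor. Compound 1 `CCOC(=O)N1CCN(CCCOc2ccc(-c3cccs3)cc2)CC1` gives 33100 nM. Among the compounds with values here, compound 2 `CCOC(=O)N1CCN(CCCOc2ccc(-c3ccc(OC)cc3)cc2)CC1` gives 100000 nM; the one measured single-point step, a 3.0-fold higher number from compound 1 to compound 2 (0.48 log units; beyond the scatter), concerns the aromatic group at the far end of the molecule. Compound 3 `C[C@@H]1CC[C@@H](C)N1CCCOc1ccc(-c2ccc(C#N)cc2)cc1` gives 9120 nM, the lowest number of the three, and its gaps to compound 1 and to compound 2 both lie beyond the scatter.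

Compound 4 `CC1CCN(CCCOc2ccc(-c3ccc(C#N)cc3)cc2)CC1` differs from compound 3 only in the amine ring: 4-methylpiperidin-1-yl in place of 2,5-dimethylpyrrolidin-1-yl on a saturated chain carbon, three bonds along the chain from an oxygen on an aromatic ring. Within the data shown here, no measured step touches this part of the molecule; the change from compound 1 to compound 2 alters the aromatic group instead, so it offers no direct guide here. With nothing in the measured data pointing to a large shift in either direction, the step is expected to be a 1.3-fold higher number from compound 3 to compound 4 (0.12 log units; within the scatter), within the scatter. Compound 4 is therefore estimated at 12000 nM, expected to fall between 4000 nM and 40000 nM.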

Compound 4, inhibition constant: 9120 nM
Estimate against measurement, compound 4: 1.3-fold (0.12 log units) above, within the range that was stated.
By their numbers in this assay, from the lowest: compounds 3 and 4 (each within the scatter of the next); then compound 1; then compound 2.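

In this assay, putting 4-methylpiperidin-1-yl in place of 2,5-dimethylpyrrolidin-1-yl on this saturated chain carbon shows no change at the digits printed from compound 3 to compound 4 (within the scatter). Within the data shown here, this is the first measured change at the amine ring, and it shows that, for this pair, a six-membered ring with one methyl group and no defined stereocentres gives the same reading as a five-membered ring with two methyl groups and two defined stereocentres. No measurement is available to explain this match between the two rings.

A single pair cannot show whether the amine ring can be varied more widely, for example to an unsubstituted piperidine, a morpholine or an open-chain diethylamine. As far as these compounds go, a longer chain between the oxygen and the amine also remains untested in these compounds, as does any other amine ring paired with this same nitrile-bearing end.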